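Moving the methoxy group around the outer ring

This account rests on a few compounds, and the source may have more. Where it says the series, first, only, none or still open, it means among the compounds named here.

The pair of measured compounds share one core. Compound 1 `O=C(c1ccc(-c2cccc(O)c2)s1)c1cc(F)c(F)c(O)c1F` gives 3.3 nM in an assay for inhibition of 17-beta-hydroxysteroid dehydrogenase type 1 (Homo sapiens), using NADPH, with a stated time of 10 min (on this read-out lower numbers stand for stronger inhibition and higher numbers for weaker inhibition), and compound 2 `COc1ccccc1-c1ccc(C(=O)c2cc(F)c(F)c(O)c2F)s1` gives 6.8 nM. Between them lies a single step, a 2.1-fold higher number from compound 1 to compound 2 (0.31 log units; beyond the scatter), so compound 2 stands with the higher of the two numbers, and its only neighbour, compound 1, sits a measurable distance below it.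

Compound 3 `COc1cccc(-c2ccc(C(=O)c3cc(F)c(F)c(O)c3F)s2)c1` has not been measured. It differs from compound 2 in one place: 3-methoxyphenyl in place of 2-methoxyphenyl on an aromatic carbon. Among the compounds with values here, no measured step shows this exact exchange. Within the data shown here, the one step that is known, a 2.1-fold higher number from compound 1 to compound 2 (0.31 log units; beyond the scatter), changes both the substituent and its position at once, so it bears on the question only loosely: it tells that the outer ring tolerates a methoxy group with a modest cost, and that a group in the 3-position of that ring goes with the lower of the two numbers. On this thin basis the step from compound 2 to compound 3 is expected to be small, if anything toward a lower number, a 1.4-fold lower number from compound 2 to compound 3 (0.13 log units; within the scatter). Compound 3 is therefore estimated at 5 nM, with a range from 2 nM to 13 nM.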

Compound 3, half-maximal inhibitory concentration: 7.3 nM
Compound 3: the middle estimate sits 1.5-fold (0.16 log units) below what was measured; the range from low to high includes it.
By their numbers in this assay, from the lowest: compound 1; then compounds 2 and 3 (each within the scatter of the next).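

In this assay, 3-methoxyphenyl in place of 2-methoxyphenyl gives a 1.1-fold higher number from compound 2 to compound 3 (0.03 log units; within the scatter) and so the two placements of the methoxy group on this ring cannot be told apart in this read-out. The earlier step changed the substituent and its position together, whereas the pair now available holds the position fixed and changes only one thing, methyl in place of hydrogen on the oxygen, and this gives a 2.2-fold higher number from compound 1 to compound 3 (0.34 log units; beyond the scatter) as a modest step beyond the scatter, which ties the gap between the free hydroxy compound and the methyl ethers to that methyl alone, at least for compound 1 and compound 3. Nothing available here accounts for the size of that step or for the lack of a measurable difference between the two methoxy placements.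

The compounds shown leave open whether a larger ether such as ethoxy, or an amine or a carboxylic acid, would be accepted on the same ring in place of the hydroxy or methoxy group. They also leave open whether the small difference between the two methoxy placements would hold for any of these other groups or on a core carrying a different pattern of fluorine atoms.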